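Moving a Fluorine on the Sulfonyl Aryl of Compound 2

This account rests on a few compounds, and the source may have more. Where it says the series, first, only, none or still open, it means among the compounds named here.

Of the compounds shown here, three have been measured in an ADME assay on microsomes from liver (Homo sapiens) for metabolic stability, tested at 2.5 uM; on this read-out lower numbers stand for slow clearance and higher numbers for fast clearance. Compound 2 `O=S(=O)(c1cc(F)cc(F)c1)c1cnc2cc(F)ccc2c1-c1ccc(Cl)cc1` gives 0.03 mL/min in this assay, the lowest of the three numbers, with both other compounds lying beyond the scatter above it. Compound 1 `O=S(=O)(c1ccc(F)c(Cl)c1)c1cnc2c(F)cccc2c1-c1ccccc1F` gives 1.39 mL/min in this assay. Compound 3 `COc1cccc(-c2c(S(=O)(=O)c3cc(F)cc(F)c3)cnc3cc(F)ccc23)c1` gives 1.81 mL/min in this assay. Among the measured compounds shown here, the only single-group step among them, a 60-fold higher number from compound 2 to compound 3 (1.78 log units; beyond the scatter), concerns the aryl on an aromatic carbon of the shared core, not the aryl on the sulfonyl sulfur.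

Compound 4 `O=S(=O)(c1ccc(F)c(F)c1)c1cnc2cc(F)ccc2c1-c1ccc(Cl)cc1` has not yet been measured. It differs from compound 2 as follows: 3,4-difluorophenyl in place of 3,5-difluorophenyl on a sulfonyl sulfur. For the measured compounds named here, no measured step changes a group on the sulfonyl sulfur alone, so nothing here tells how large such a step is; the one measured step acts elsewhere. The account therefore expects no step beyond the scatter, while allowing a wide range for an untested position. Compound 4 is estimated at 0.06 mL/min in this assay, between 0.015 mL/min and 0.4 mL/min. This estimate means an expected 2.0-fold higher number from compound 2 to compound 4 (0.30 log units; within the scatter).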

Compound 4, intrinsic clearance in a liver preparation (reported as CLH), per the amount of preparation that the assay uses: 0.01 mL/min
Compound 4: middle estimate off by 6.0-fold (0.78 log units), on the high side; measured number below the stated range.
By their numbers in this assay, from the lowest: compound 4; then compound 2; then compounds 1 and 3 (each within the scatter of the next).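

In this assay the group on the sulfonyl sulfur proves able to move the number even when no atom is gained or lost: 3,4-difluorophenyl in place of 3,5-difluorophenyl gives a 3.0-fold lower number from compound 2 to compound 4 (0.48 log units; beyond the scatter), a modest step but one beyond the scatter. Among the compounds shown here, this is the first step read at this position, and it runs downward, so the low number of compound 2 is not tied to the 3,5-difluorophenyl group. The compounds shown offer no measured evidence that would account for this step.

On these data alone, it remains open whether the same change would give a similar step with the 3-methoxyphenyl group of compound 3 on the shared core. Also open, as far as these compounds go, is how this assay would respond to an amine or a carboxylic acid on the aryl at the sulfonyl sulfur.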